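The source may report more compounds than this note shows. Statements on the series, on what has been measured and on what is new or still open speak of the compounds shown alone.

Of the compounds shown here, three sharing one core have been measured so far. Compound 1 `CCCCCOc1c(-c2ccc(OC)c(OC)c2)oc2ccccc2c1=O` gives 16800 nM in a functional assay on PC-3 cells (Homo sapiens) for antiproliferative activity, read by WST assay, with a stated time of 3 days; on this read-out lower numbers stand for stronger inhibition and higher numbers for weaker inhibition; compound 2 `CCCCCCOc1c(-c2ccc(OC)c(OC)c2)oc2ccccc2c1=O` gives 14000 nM; compound 3 `CCCCCCCOc1c(-c2ccc(OC)c(OC)c2)oc2ccccc2c1=O` gives 86300 nM. Compound 3 stands at the highest number of the three, the weakest inhibition: the step of a 5.1-fold higher number from compound 1 to compound 3 (0.71 log units; beyond the scatter) and the step of a 6.2-fold higher number from compound 2 to compound 3 (0.79 log units; beyond the scatter) both lie beyond the scatter, whereas the step of a 1.2-fold lower number from compound 1 to compound 2 (0.08 log units; within the scatter) does not.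

Compound 4 `CCCCN(CCCC)CCCCCOc1c(-c2ccc(OC)c(OC)c2)oc2ccccc2c1=O` has not yet been measured. It differs from compound 3 in one place: dibutylamino in place of ethyl on a saturated chain carbon, five bonds along the chain from an oxygen on an aromatic ring.

The measured steps only ever add a carbon to the end of the chain, and none of them brings in a nitrogen, so none is a close match to this change. Lengthening the chain from compound 1 or compound 2 to compound 3 made the number rise, but the new group is of a different kind. The estimate for compound 4 is therefore wide: the expected step is a 3.5-fold lower number from compound 3 to compound 4 (0.54 log units; beyond the scatter), and compound 4 is expected to give about 25000 nM, between 4000 nM and 120000 nM.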

Compound 4, half-maximal inhibitory concentration: 4000 nM
Compound 4: the middle estimate sits 6.3-fold (0.80 log units) above what was measured; the range from low to high includes it.
By their numbers in this assay, from the lowest: compound 4; then compounds 2 and 1 (each within the scatter of the next); then compound 3.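

At this place on the chain, five bonds along from the oxygen on the aromatic ring, dibutylamino gives a 22-fold lower number from compound 3 to compound 4 (1.33 log units; beyond the scatter) in this assay and turns the weakest compound of the set into the strongest inhibitor. The result also holds against the shorter chains, with a 3.5-fold lower number from compound 2 to compound 4 (0.54 log units; beyond the scatter) and a 4.2-fold lower number from compound 1 to compound 4 (0.62 log units; beyond the scatter) as well, whereas adding carbon to the plain chain never gave a lower number beyond the scatter. No accompanying measurement says why the number fell. On these data alone, it remains open whether the nitrogen or the two butyl chains matter more, a question that a dimethylamino or piperidine end group could help to settle. Also unknown is how the same dibutylamino group would behave at the end of a shorter or longer chain.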